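A few compounds are considered here, and "the series" means these few. Any claim that something is new, unique, unknown or untested is made for them only; others in the source may bear on it.

Measured so far in a functional assay on U-87MG ATCC cells (Homo sapiens) for antiproliferative activity, read by MTT assay, with a stated time of 48 h; a lower number here means a stronger inhibitor, a higher number a weaker inhibitor:
- compound 1, `COc1ccc(N/C=C\C(=O)c2cn(-c3ccccc3)nc2-c2ccccc2)cc1`, gives > 50000 nM
- compound 2, `O=C(/C=C\Nc1ccc(Cl)cc1)c1cn(-c2ccccc2)nc1-c1ccc(F)cc1`, gives 8900 nM
- compound 3, `COc1cc(N/C=C\C(=O)c2cn(-c3ccccc3)nc2-c2ccc(F)cc2)cc(OC)c1OC`, gives 12600 nM

The value of compound 1 is a limit of the assay, not a number; it sits at the limit of > 50000 nM in this assay, at which 1 of the 3 values shown sits. Among the two numbers, compound 3 has the higher one, with compound 2 nearest and within the scatter, so no order between them can be read.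

Compound 4, `COc1ccc(-c2nn(-c3ccccc3)cc2C(=O)/C=C\Nc2cc(OC)c(OC)c(OC)c2)cc1`, differs from compound 3 by methoxy in place of fluoro on an aromatic carbon. Going by the values given here, no measured pair shows this change alone, so nothing sets its size; the expectation is a step from compound 3 to compound 4 of a 1.3-fold higher number from compound 3 to compound 4 (0.10 log units; within the scatter), not beyond the scatter in either direction. Compound 4 is estimated at 16000 nM, between 5000 nM and 50000 nM.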

Compound 4, half-maximal inhibitory concentration: > 50000 nM
Compound 4: no number, only a limit; the forecaster's own chance of this, stated with the estimate: 25%; middle value at least 3.1-fold (0.49 log units) away from the limit.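

Compound 4 gives a limit of the assay, not a number. In this assay, going by these compounds alone, the change from 4-fluorophenyl to 4-methoxyphenyl gives an at least 3.9-fold higher number from compound 3 to compound 4 (0.59 log units; beyond the scatter), the first step between compounds that differ in one place, and it shows that this position, para to a large group, is sensitive to the group it carries. The step gives only a minimum size, not a full one: the limit of > 50000 nM in this assay, at which 2 of the 4 values shown sit.

As far as these compounds go, how far the true value of compound 4 lies past that limit stays open. Also open, from the compounds shown here alone, is whether an amine, a hydroxyl or a longer alkoxy chain at this position would behave like fluoro or like methoxy.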